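The source may hold more compounds than are shown below. What is called first, only, known or untested is meant among the compounds shown, and "the series" means these compounds.

Three related compounds have been tested in an assay on isolated protein for inhibition of disintegrin and metalloproteinase domain-containing protein 10 (Homo sapiens); a lower number here means a stronger inhibitor, a higher number a weaker inhibitor. Compound 1 `O=C(NO)[C@H]1CC(CC(=O)N2CCCC2)CN[C@@H]1C(=O)N1CC[C@H](c2ccccc2)C1` gives 14 nM. Compound 2 `CN(C(=O)c1ccccc1)C1CN[C@H](C(=O)N2CC[C@H](c3ccccc3)C2)[C@@H](C(=O)NO)C1` gives 84 nM. Compound 3 `O=C(NO)[C@H]1CC(CC(=O)N2CCCC2)CN[C@@H]1C(=O)N1CC=C(c2ccccc2)CC1` gives 17 nM. Of these three numbers, compound 3 sits in the middle: compound 1 lies within the scatter of it, so the two cannot be told apart, while compound 2 stands clearly higher, beyond the scatter.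

The step now in question leads from compound 3 to compound 4 `CC(C)OC(=O)N(C)C1CN[C@H](C(=O)N2CC=C(c3ccccc3)CC2)[C@@H](C(=O)NO)C1`. The change is (isopropoxycarbonyl)(methyl)amino in place of ((pyrrolidin-1-yl)carbonyl)methyl on a saturated ring carbon.

Among the compounds with values here, one measured step bears on this: a 6.0-fold higher number from compound 1 to compound 2 (0.78 log units; beyond the scatter). There, as here, the pyrrolidinylcarbonylmethyl group on the saturated ring carbon gave way to a methyl-bearing nitrogen carrying a carbonyl, and the number rose. Compound 4 carries a carbamate of that kind in place of the amide of compound 2, so a rise of a similar order is expected, with the direction toward weaker inhibition more secure than its exact size. The step from compound 3 to compound 4 in this assay is therefore expected to be a 4.7-fold higher number from compound 3 to compound 4 (0.67 log units; beyond the scatter). For compound 4 the estimate is 80 nM, with a range from 30 nM to 250 nM.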

Compound 4, half-maximal inhibitory concentration: 11 nM
The estimate for compound 4 lay 7.3-fold (0.86 log units) above the measured number, outside the stated range (below it).
By their numbers in this assay, from the lowest: compounds 4, 1 and 3 (each within the scatter of the next); then compound 2.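

In this assay the result is a 1.5-fold lower number from compound 3 to compound 4 (0.19 log units; within the scatter) and so, on this saturated ring carbon, (isopropoxycarbonyl)(methyl)amino can stand in place of ((pyrrolidin-1-yl)carbonyl)methyl without a change the assay can resolve. Leaving that group for a methyl-bearing nitrogen with a carbonyl therefore does not by itself raise the number, even though the earlier step was a 6.0-fold higher number from compound 1 to compound 2 (0.78 log units; beyond the scatter) and lay beyond the scatter. No measurement shown here explains the contrast between these two steps.

The compounds shown leave open whether the group entering or the large group at the other ring atom separates the two steps, as no pair shares one large group while carrying both entering groups. As far as these compounds go, how a plain amino group or a carboxylic acid would fare at this ring carbon also remains unknown.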